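The compounds below may be only part of what the source reports. "The series", "measured", "known", "first", "only" and "open" are said of these compounds alone.

Three analogues share one core. Compound 1 `O=Cc1c(-c2ccc(Br)cc2)nc2sc(Cc3ccc(Cl)cc3)nn12` carries a formyl group and a 4-bromophenyl group; in a functional assay on HeLa cells (Homo sapiens) for cytotoxicity, with a stated time of 72 h (on this read-out higher numbers stand for weaker inhibition and lower numbers for stronger inhibition), compound 1 gives 4200 nM. Compound 2 `COc1ccc(-c2nc3sc(Cc4ccc(Cl)cc4)nn3c2C=O)cc1` differs from it by methoxy in place of bromo on an aromatic carbon and in this assay compound 2 gives 6000 nM. That step is a 1.4-fold higher number from compound 1 to compound 2 (0.15 log units; within the scatter). Compound 3 `N#CSc1c(-c2ccc(Br)cc2)nc2sc(Cc3ccc(Cl)cc3)nn12` differs from compound 1 by cyanosulfanyl in place of formyl on an aromatic carbon and in this assay compound 3 gives 22000 nM, the highest of the three numbers. That step is a 5.2-fold higher number from compound 1 to compound 3 (0.72 log units; beyond the scatter).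

Compound 4 `COc1ccc(-c2nc3sc(Cc4ccc(Cl)cc4)nn3c2SC#N)cc1` is not yet measured. It differs from compound 3 by methoxy in place of bromo on an aromatic carbon. The place of the change reads word for word as for the pair already measured, so this is the same change, now made on the core of compound 3, whose difference from the core of compound 1 is given with cyanosulfanyl in place of formyl on an aromatic carbon. One earlier instance is all there is to go on. The expected step is a 1.3-fold higher number from compound 3 to compound 4 (0.10 log units; within the scatter), resting on the earlier step of a 1.4-fold higher number from compound 1 to compound 2 (0.15 log units; within the scatter), which lay within the scatter. For compound 4 in this assay the estimate is 28000 nM, expected between 12000 nM and 65000 nM.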

Compound 4, half-maximal inhibitory concentration: 9000 nM
Estimate against measurement, compound 4: 3.1-fold (0.49 log units) above, outside the stated range (below it).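

In this assay, methoxy in place of bromo gives a 2.4-fold lower number from compound 3 to compound 4 (0.39 log units; beyond the scatter), so the step seen on the formyl core does not carry over to the cyanosulfanyl core in size or direction: the same change on two cores in this assay, a 1.4-fold higher number (0.15 log units; within the scatter) from compound 1 to compound 2 and a 2.4-fold lower number (0.39 log units; beyond the scatter) from compound 3 to compound 4, 3.5-fold (0.54 log units) apart, beyond the scatter of two such steps Read along the other edge, cyanosulfanyl in place of formyl gives a 1.5-fold higher number from compound 2 to compound 4 (0.18 log units; within the scatter), so this change also depends on its surroundings, here on whether the ring carries bromo or methoxy: the same change on two cores in this assay, a 5.2-fold higher number (0.72 log units; beyond the scatter) from compound 1 to compound 3 and a 1.5-fold higher number (0.18 log units; within the scatter) from compound 2 to compound 4, 3.5-fold (0.54 log units) apart, beyond the scatter of two such steps Both comparisons rest on the same four compounds, so they show one dependence between the two places rather than two separate findings, and they give neither a cause for it nor a rule for any further core.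

Open, from the compounds shown here alone, is whether this dependence persists with other groups in place of formyl and cyanosulfanyl, such as a nitrile or a carboxylic acid, or with others in place of bromo and methoxy, such as an amine or a longer alkoxy chain. Going by these compounds, only one read-out appears here, so whether the dependence extends beyond it also remains open.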